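The source may hold more compounds than are shown below. What is called first, only, known or untested is meant among the compounds shown, and "the series" means these compounds.

Of the compounds shown here, three sharing one core have been measured in a physicochemical assay for lipophilicity; on this read-out lower numbers stand for lower lipophilicity and higher numbers for higher lipophilicity. In that assay, compound 2 `COc1ccc(NC(=S)Nc2ccc3nc(Oc4ccc(F)cc4C(C)O)c(Cc4ccccc4)cc3c2)cc1` gives 7.86, and compound 3 `CC(O)c1cc(F)ccc1Oc1nc2ccc(NS(=O)(=O)c3cccc(C(F)(F)F)c3)cc2cc1Cc1ccccc1` gives 7.69, so these two lie within the usual scatter of each other. Compound 1 `COc1cccc(NC(=O)Nc2ccc3nc(Oc4ccc(F)cc4C(C)O)c(Cc4ccccc4)cc3c2)c1` gives 6.72, which is lower than the other two by more than the scatter. Compound 2 therefore sits in the upper pair of the series.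

The next compound to be measured is compound 4 `COc1ccccc1NC(=O)Nc1ccc2nc(Oc3ccc(F)cc3C(C)O)c(Cc3ccccc3)cc2c1`, which differs from compound 2 in one place: a group of 11 heavy atoms (8 carbon, 1 nitrogen, 2 oxygen; one six-membered aromatic ring of carbon only) in place of a group of 11 heavy atoms (8 carbon, 1 nitrogen, 1 oxygen, 1 sulfur; one six-membered aromatic ring of carbon only), on a nitrogen on an aromatic ring. The group that leaves has no common name, and the group that enters is (2-methoxyphenyl)carbamoyl. Both are on a nitrogen on an aromatic ring.

Among the compounds with values here, only one measured step bears on this change, namely a number 1.14 log units higher from compound 1 to compound 2 (beyond the scatter), which is large and beyond the scatter. That step brought in a group with sulfur in place of a group with a second oxygen, and the change to compound 4 runs the opposite way. Within the data shown here, compound 3 is linked to the others by no single-place step, so it gives no guide. Among the measured compounds shown here, with only one step to go on, a large fall of similar size is expected, and the estimated step is a number 1.06 log units lower from compound 2 to compound 4 (beyond the scatter). Compound 4 is therefore expected to read 6.8, within an estimated range of 6.3 to 7.3.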

Compound 4, partition coefficient: 6.72
For compound 4 the middle estimate is 0.08 log units above the measured one; the range from low to high includes it.
By their numbers in this assay, from the lowest: compounds 1 and 4 (each within the scatter of the next); then compounds 3 and 2 (each within the scatter of the next).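

In this assay, the (2-methoxyphenyl)carbamoyl group on a nitrogen on an aromatic ring gives a second large step at this position, a number 1.14 log units lower from compound 2 to compound 4 (beyond the scatter), so the gap between the sulfur-bearing group of compound 2 and an oxygen-bearing group no longer rests on compound 1 alone. Within the data shown here, the other new comparison is the first at this position to stay within the scatter: with 2-methoxyphenyl in place of 3-methoxyphenyl on an amide-type nitrogen, the result is no change at the digits printed from compound 1 to compound 4 (within the scatter). Among compound 1, compound 2 and compound 4, the large steps therefore both involve the sulfur-bearing group, while the exchange of one methoxyphenyl group for the other leaves the reading within the scatter.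

Nothing shown gives a measured reason for either the large steps or the step within the scatter. The compounds shown leave open whether the sulfur-bearing group would keep its distance from the oxygen-bearing groups when paired with other ring substituents, and how an amine or a carboxylic acid in place of the methoxy group would read.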